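Heteroaryl amide variation on the urotensin-2 series

The source may hold more compounds than are shown below. What is called first, only, known or untested is meant among the compounds shown, and "the series" means these compounds.

Within the data shown here, compound 2 `O=C(NC1CCN(Cc2ccc(OC3CCNCC3)c(Br)c2)CC1)c1cscn1` gives 970 nM in an assay on HEK293 cells for displacement of a labelled ligand from Urotensin-2 receptor (Homo sapiens), read by fluorescence, with a stated time of 90 min (on this read-out lower numbers stand for stronger inhibition and higher numbers for weaker inhibition), the highest of the two numbers so far; compound 1 `O=C(NC1CCN(Cc2ccc(OC3CCNCC3)c(Br)c2)CC1)c1cccs1` gives 130 nM. Among the measured compounds shown here, the single measured step, a 7.5-fold higher number from compound 1 to compound 2 (0.87 log units; beyond the scatter), shows that the heteroaryl on the carbonyl carbon moves the read-out well beyond the scatter. Compound 3 `O=C(NC1CCN(Cc2ccc(OC3CCNCC3)c(Br)c2)CC1)c1ccccn1` carries pyridin-2-yl in place of 1,3-thiazol-4-yl on a carbonyl carbon. For the measured compounds named here, no measured step covers a six-membered ring here, so only the direction of that first step is a guide: a return toward the number of compound 1 is expected, modest in size, as a 2.4-fold lower number from compound 2 to compound 3 (0.38 log units; beyond the scatter). Compound 3 is therefore estimated at 400 nM, within 120 nM to 1500 nM.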

Compound 3, half-maximal inhibitory concentration: 120 nM
Compound 3: middle estimate off by 3.3-fold (0.52 log units), on the high side, within the range that was stated.
By their numbers in this assay, from the lowest: compounds 3 and 1 (each within the scatter of the next); then compound 2.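

In this assay, a six-membered aromatic ring on the carbonyl carbon is accepted: an 8.1-fold lower number from compound 2 to compound 3 (0.91 log units; beyond the scatter) is a step beyond the scatter, while a 1.1-fold lower number from compound 1 to compound 3 (0.03 log units; within the scatter) puts pyridin-2-yl level with thiophen-2-yl. Ring size alone therefore does not set the number here, and compound 2 is the one that goes against its two neighbours, with two hetero atoms in its ring where compound 1 and compound 3 have one. Nothing at hand explains this difference.

Open, going by these compounds, is how phenyl, with no ring hetero atom, would compare on the carbonyl carbon. Also open, on these data alone, is whether pyridin-3-yl or pyridin-4-yl would stay level with pyridin-2-yl.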